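Fluoro for methyl on the benzoxazole of compound 1

This account rests on a few compounds, and the source may have more. Where it says the series, first, only, none or still open, it means among the compounds named here.

Compound 1 `Cc1ccc2oc(-c3ccc(NC(=O)CN4CCN(CCN(C)C)CC4)cc3)nc2c1`: 1630 nM
Compound 2 `Cc1ccc2oc(-c3ccc(NC(=O)CN4CCN(CCN(C)C)CC4)c(C)c3)nc2c1`: 16700 nM
Compound 3 `Cc1cc(-c2nc3cc(F)ccc3o2)ccc1NC(=O)CCl`: a limit, > 100000 nM

In a functional assay on C6 cells (Rattus norvegicus) for cytotoxicity, read by MTT assay, with a stated time of 24 h (on this read-out higher numbers stand for weaker inhibition and lower numbers for stronger inhibition), compound 1 gives 1630 nM and stands lowest of the two numbers. Its nearest neighbour is compound 2, reached through a 10-fold higher number from compound 1 to compound 2 (1.01 log units; beyond the scatter). Compound 3 reaches only the limit of > 100000 nM in this assay, at which 1 of the 3 values shown sits, and carries no number.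

Compound 4 `CN(C)CCN1CCN(CC(=O)Nc2ccc(-c3nc4cc(F)ccc4o3)cc2)CC1` is compound 1 with fluoro in place of methyl on an aromatic carbon, so that 5-methyl-1,3-benzoxazol-2-yl becomes 5-fluoro-1,3-benzoxazol-2-yl. Within the data shown here, no measured step touches this part of the shared core, and compound 3 differs from compound 1 in more than one place, so it cannot be read as that step. The expected change in this assay is therefore none beyond the scatter. Compound 4 is estimated at 2000 nM, between 700 nM and 6000 nM, which means an expected step of a 1.2-fold higher number from compound 1 to compound 4 (0.09 log units; within the scatter).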

Compound 4, half-maximal inhibitory concentration: 4390 nM
The estimate for compound 4 lay 2.2-fold (0.34 log units) below the measured number, and the stated range covers the measured number.
By their numbers in this assay, from the lowest: compound 1; then compound 4; then compound 2. At a limit, above all of these: compound 3.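

In this assay, among these compounds, the position is not indifferent: 5-fluoro-1,3-benzoxazol-2-yl in place of 5-methyl-1,3-benzoxazol-2-yl brings a 2.7-fold higher number from compound 1 to compound 4 (0.43 log units; beyond the scatter) and so shows that this part of the shared core moves the number, which no earlier pair could show. Methyl and fluoro are therefore not interchangeable here, with methyl giving the lower number of the two. Nothing measured here bears on why this step occurs.

As far as these compounds go, whether chloro, methoxy or an amine at this position would give a lower number than methyl remains open.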